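Changing the Sulfur Side Chain

A few compounds are considered here, and "the series" means these few. Any claim that something is new, unique, unknown or untested is made for them only; others in the source may bear on it.

In a functional assay on MGC-803 cells (Homo sapiens) for inhibition, read by MTT assay, with a stated time of 72 h (a lower number here means a stronger inhibitor, a higher number a weaker inhibitor), compound 1 `C#CCSc1nc(Nc2cccc(Cl)c2)c2ccncc2n1` gives 2190 nM and compound 2 `C#CCSc1nc(Nc2cccc(OC)c2)c2ccncc2n1` gives 2070 nM, so compound 2 stands level with compound 1, within the scatter. Compound 3 `COc1cccc(Nc2nc(SCC3CCCCC3)nc3cnccc23)c1` keeps the methoxy of compound 2 but carries cyclohexyl in place of ethynyl on a saturated chain carbon bound to a sulfur. Among the compounds with values here, the only measured step, a 1.1-fold lower number from compound 1 to compound 2 (0.02 log units; within the scatter), concerns methoxy in place of chloro on an aromatic carbon, a different place, so it does not show the size of this change. A modest move to a higher number in this assay is expected, an estimated 1.9-fold higher number from compound 2 to compound 3 (0.29 log units; within the scatter). For compound 3 the estimate is 4000 nM, with an expected range of 1000 nM to 16000 nM.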

Compound 3, half-maximal inhibitory concentration: 23700 nM
For compound 3 the middle estimate is 5.9-fold (0.77 log units) below the measured one, outside the stated range (above it).
By their numbers in this assay, from the lowest: compounds 2 and 1 (each within the scatter of the next); then compound 3.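

In this assay, the sulfur side chain proves to be a sensitive position: cyclohexyl in place of ethynyl gives an 11-fold higher number from compound 2 to compound 3 (1.06 log units; beyond the scatter), so compound 3 is clearly the weaker inhibitor. Within the data shown here, the earlier methoxy for chloro change on an aromatic carbon stayed within the scatter, so this is the first change here with a clear effect. No available evidence explains why the number rises so much.

On these data alone, with a single replacement on this chain, the trend remains unknown. A short methyl group, a phenyl ring or a chain ending in an amine could each behave differently.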